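Fluoro in Place of Chloro on an Aromatic Carbon

The source may hold more compounds than are shown below. What is called first, only, known or untested is meant among the compounds shown, and "the series" means these compounds.

- compound 1 `NS(=O)(=O)c1ccc(N2N=C(c3ccccc3)CC2c2ccccc2F)cc1` gives 42000 nM in an ADME assay on MT4 cells (Homo sapiens) for cytotoxicity, read by MTT assay, with a stated time of 96 h; a lower number here means that less compound is tolerated, a higher number that more compound is tolerated
- compound 2 `NS(=O)(=O)c1ccc(N2N=C(c3ccc(OCc4ccccc4)cc3)CC2c2ccccc2Cl)cc1` gives 26000 nM in this assay

The two numbers lie within the scatter of each other, so compound 2 (26000 nM) stands level with compound 1 (42000 nM). Compound 3 (`NS(=O)(=O)c1ccc(N2N=C(c3ccc(OCc4ccccc4)cc3)CC2c2ccccc2F)cc1`) follows from compound 2 with fluoro in place of chloro on an aromatic carbon, ortho to a large group (fluoro in place of chloro on an aromatic carbon). Within the data shown here, no measured pair shows this change, and no shift beyond the scatter is expected in this assay here. The expected change is small (a 1.2-fold higher number from compound 2 to compound 3 (0.06 log units; within the scatter)). Compound 3 is estimated at (30000 nM), with an expected range from (14000 nM) to (65000 nM).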

Compound 3, half-maximal cytotoxic concentration: 39000 nM
For compound 3 the middle estimate is 1.3-fold (0.11 log units) below the measured one; low and high end bracket the measured number.
By their numbers in this assay, from the lowest: compounds 2, 3 and 1 (each within the scatter of the next).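

In this assay, fluoro in place of chloro gives a 1.5-fold higher number from compound 2 to compound 3 (0.18 log units; within the scatter) and so, at this position, the two halogens cannot be told apart. With fluoro in place, benzyloxy in place of hydrogen gives a 1.1-fold lower number from compound 1 to compound 3 (0.03 log units; within the scatter) and thus no reading beyond the scatter for that group either. Nothing available here accounts for these results. The compounds shown leave open whether an amine or a carboxylic acid in place of the halogen at this position would move the number beyond the scatter.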